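Aryl exchange on the ester chain: cytotoxicity notes

A few compounds are considered here, and "the series" means these few. Any claim that something is new, unique, unknown or untested is made for them only; others in the source may bear on it.

Compound 2 `O=C(/C=C/c1cccc(F)c1)OCCc1c(-c2ccccc2Cl)c2cc(Cl)ccc2[nH]c1=O` gives in an ADME assay on HepG2 2.2.15 cells (Homo sapiens) for cytotoxicity (on this read-out higher numbers stand for lower toxicity in this test and lower numbers for higher toxicity in this test), only a limit, > 1600000 nM, with no number beneath it (the limit of > 1600000 nM in this assay, at which 1 of the 2 values shown sits). Within the data shown here, compound 1 `O=C(OCCc1c(-c2ccccc2Cl)c2cc(Cl)ccc2[nH]c1=O)C1CCCCC1` gives 38000 nM in this assay, and the one measured change on the carbonyl carbon is an at least 42-fold higher number from compound 1 to compound 2 (1.62 log units; beyond the scatter). Compound 3 `O=C(/C=C/c1ccc(C(F)(F)F)cc1)OCCc1c(-c2ccccc2Cl)c2cc(Cl)ccc2[nH]c1=O` differs from compound 2 by 4-(trifluoromethyl)phenyl in place of 3-fluorophenyl on a double-bonded chain carbon bound to a double-bonded chain carbon. Among the measured compounds shown here, no measured step covers this aryl exchange, and compound 2 already stands at the limit, so no step beyond the scatter is expected: a number no higher from compound 2 to compound 3 (the limit leaves the size open). Compound 3 is therefore expected at 1600000 nM, within 400000 nM to 3200000 nM, most likely reported again as a limit.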

Compound 3, half-maximal cytotoxic concentration: > 1400000 nM
Compound 3 gave a limit, no number (the forecaster's own chance of this, stated with the estimate: 75%); the middle value is on the limit's open side.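

In this assay compound 3 also gives only a limit, > 1400000 nM. With 4-(trifluoromethyl)phenyl on the double-bonded chain carbon, the exchange on the carbonyl carbon still gives an at least 36-fold higher number from compound 1 to compound 3 (1.56 log units; beyond the scatter), so the large change is not confined to the 3-fluorophenyl compound. The step between compound 2 and compound 3 cannot be read, as both values are limits.

Still open, from the compounds shown here alone, is whether an amine or a carboxylic acid on the aryl ring would keep this read-out at a limit. A longer chain on the carbonyl carbon is equally untested in the compounds shown.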